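The compounds below may be only part of what the source reports. "The series", "measured", "known", "first", "only" and "open" are said of these compounds alone.

Among the compounds with values here, compound 2 `Cc1cccc(-c2cnc(C(=O)CCCCCCc3ccccc3)o2)n1` gives the lowest of the two numbers measured so far in an assay (Rattus norvegicus) for inhibition of Fatty-acid amide hydrolase 1 (Homo sapiens) (a higher number here means a weaker inhibitor, a lower number a stronger inhibitor), at 3.3 nM. Within the data shown here, its only neighbour is compound 1 `O=C(CCCCCCc1ccccc1)c1ncc(-c2ccccc2F)o1`, which in this assay gives 110 nM; the single measured step, a 33-fold lower number from compound 1 to compound 2 (1.52 log units; beyond the scatter), came from putting 6-methylpyridin-2-yl in place of 2-fluorophenyl on an aromatic carbon.

Compound 3 `O=C(CCCCCCc1ccccc1)c1ncc(I)o1` differs from compound 2 as follows: iodo in place of 6-methylpyridin-2-yl on an aromatic carbon. Among the measured compounds shown here, this change touches the same position as the one measured step, which shows that the group on this carbon of the shared core can move the inhibition constant a long way. For the measured compounds named here, no measured pair, however, removes the whole aromatic group and leaves a single atom in its place, so the direction can only be inferred. Since the 6-methylpyridin-2-yl of compound 2 coincides with the strongest number, its loss is expected to cost potency, so a rise in the inhibition constant is expected, of roughly a 30-fold higher number from compound 2 to compound 3 (1.48 log units; beyond the scatter). Compound 3 is therefore estimated to give about 100 nM in this assay, within a range of 15 nM to 700 nM.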

Compound 3, inhibition constant: 3 nM
Estimate against measurement, compound 3: 33-fold (1.52 log units) above; measured number outside the range, below it.
By their numbers in this assay, from the lowest: compounds 3 and 2 (each within the scatter of the next); then compound 1.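

In this assay, the step of a 1.1-fold lower number from compound 2 to compound 3 (0.04 log units; within the scatter) shows that on this carbon, next to the ring oxygen, the 6-methylpyridin-2-yl group and iodo cannot be told apart, although one is a six-membered aromatic ring of 7 heavy atoms and the other a single iodine atom. Among these compounds, then, a low number does not depend on an aromatic ring at this position, and the step of a 37-fold lower number from compound 1 to compound 3 (1.56 log units; beyond the scatter) places compound 1 alone, with its 2-fluorophenyl group, as the weakest of the three, so the earlier step can no longer be read as a gain that only the 6-methylpyridin-2-yl group brings. No measurement offered here accounts for the match between the two groups or for the distance to 2-fluorophenyl.

The compounds shown leave open whether a smaller single atom on this carbon, such as chloro, bromo or plain hydrogen, would sit with iodo or with 2-fluorophenyl. They also leave open how an unsubstituted phenyl, a pyridin-2-yl without its methyl, or a carboxylic acid at the same place would read, which is what would separate the nitrogen, the methyl and the fluorine as the part that matters.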